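Shortening the Hydroxamate Arm on a Shared Core

The source may hold more compounds than are shown below. What is called first, only, known or untested is meant among the compounds shown, and "the series" means these compounds.

The study compares three compounds built on a shared core. Within the data shown here, compound 1 `C#CCN(C)CCCOc1cc(NCc2ccc(/C=C/C(=O)NO)cc2)ccc1Cl` is measured in an assay on GL26 cells for inhibition of Amine oxidase [flavin-containing] A (Homo sapiens), read by scintillation counting, with a stated time of 20 min (a higher number here means a weaker inhibitor, a lower number a stronger inhibitor), and gives 4 nM; it is the only compound here with an actual number. Compound 2 `C#CCN(C)CCCOc1cc(NC(=O)CCCCCCCCC(=O)NO)ccc1Cl` is measured in this assay too, and for compound 2 the result is < 0.1 nM, which is a limit of the assay rather than a number, so that the limit of < 0.1 nM in this assay, at which 1 of the 2 values shown sits, marks where one of the two values sits. Compound 3 `C#CCN(C)CCCOc1cc(NCc2ccc(C(=O)NO)cc2)ccc1Cl` has not yet been measured in this assay. It differs from compound 1 by hydroxycarbamoyl in place of 2-(hydroxycarbamoyl)ethenyl on an aromatic carbon, para to a large group. Among the measured compounds shown here, no step between measured compounds is available, so the size of this step is an expectation only: a modest move towards weaker inhibition, possibly no larger than the scatter, is expected. The step of a 2.5-fold higher number from compound 1 to compound 3 (0.40 log units; beyond the scatter) is the estimate. Compound 3 is accordingly estimated at 10 nM in this assay, expected to fall between 2 nM and 60 nM.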

Compound 3, half-maximal inhibitory concentration: 0.4 nM
Estimate against measurement, compound 3: 25-fold (1.40 log units) above; measured number outside the range, below it.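

In this assay, hydroxycarbamoyl in place of 2-(hydroxycarbamoyl)ethenyl on an aromatic carbon, para to a large group, gives a 10-fold lower number from compound 1 to compound 3 (1.00 log units; beyond the scatter). Among these compounds, this is the only step between measured compounds here, and it shows that inhibition responds strongly to the change at this position. The smaller group, with 4 heavy atoms in place of 6, goes with stronger inhibition, so on this core the 2-(hydroxycarbamoyl)ethenyl arm is not needed to reach this level.

Compound 2 carries a limit of the assay rather than a number and differs from the others in more than one place, so it gives no step: the limit of < 0.1 nM in this assay, at which 1 of the 3 values shown sits.
Still open, as far as these compounds go, is whether a carboxylic acid or a primary amide at this position would hold this inhibition, and whether a saturated two-carbon chain carrying the hydroxycarbamoyl would behave like either arm.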